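Cyclohexyl for Isopropyl on the Amide Chain

This account rests on a few compounds, and the source may have more. Where it says the series, first, only, none or still open, it means among the compounds named here.

The series shares one core, carried in compound 1 `CC(C)CC(=O)NCCCN1CCN(CCCNc2ccnc3cc(Cl)ccc23)CC1`, compound 2 `O=C(CCCC1CCCCC1)NCCCN1CCN(CCCNc2ccnc3cc(Cl)ccc23)CC1` and compound 3 `O=C(CCCc1ccccc1)NCCCN1CCN(CCCNc2ccnc3cc(Cl)ccc23)CC1`. The read-out followed is an ADME assay on L6 cells (Rattus norvegicus) for cytotoxicity; on this read-out higher numbers stand for weaker inhibition and lower numbers for stronger inhibition. In this assay compound 1 gives "not determined" (no result reported), and in this assay compound 2 gives "not determined" (no result reported). For the measured compounds named here, compound 3 is the only member with a result: in this assay compound 3 gives 11000 nM. Compound 1 therefore stands without a number of its own, and only compound 3 gives a point of reference for the series.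

Compound 4 `O=C(CC1CCCCC1)NCCCN1CCN(CCCNc2ccnc3cc(Cl)ccc23)CC1` has not yet been measured. It differs from compound 1 by cyclohexyl in place of isopropyl on a saturated chain carbon bound to a carbonyl carbon. Going by the values given here, no step between two measured compounds is available for this pair, so the size of the change can only be expected, not read off. The expectation is for a step in this assay no larger than the usual scatter, in no firm direction, with compound 3 as the nearest measured anchor. Compound 4 is estimated at 12000 nM, within a range from 4000 nM to 40000 nM.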

Compound 4, half-maximal inhibitory concentration: 7200 nM
Compound 4: middle estimate off by 1.7-fold (0.22 log units), on the high side; measured number inside the range.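

For the compounds shown here, the one step that can be read is a 1.5-fold lower number from compound 3 to compound 4 (0.18 log units; within the scatter), so in this assay cyclohexyl in place of phenethyl on a saturated chain carbon bound to a carbonyl carbon leaves the two compounds indistinguishable, and compound 3 is no longer the lone reference point for the series. Going by these compounds, the steps that involve compound 1 or compound 2 cannot be read, and the effect of cyclohexyl in place of isopropyl therefore remains unknown. No supporting measurement bears on what lies behind this result.

The compounds shown leave open how a primary amine or a carboxylic acid at this place on the amide chain would read in this assay. They also leave open whether the quiet step seen here would hold for a longer chain carrying the cyclohexyl ring.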